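The source may report more compounds than this note shows. Statements on the series, on what has been measured and on what is new or still open speak of the compounds shown alone.

Measured compounds:
- compound 1, `O=C(Nc1cc2cc[nH]c(=O)c2cc1Cl)C1(c2ccccc2)CCNC1` — in a functional assay on aorta (Rattus norvegicus) for inhibition (on this read-out lower numbers stand for stronger inhibition and higher numbers for weaker inhibition), compound 1 gives "not determined" (no result reported)
- compound 2, `O=C(Nc1cc2cc[nH]c(=O)c2cc1Cl)C1CNCC1c1ccccn1` — in this assay compound 2 gives 210 nM
- compound 3, `O=C(Nc1cc2cc[nH]c(=O)c2cc1Cl)C1CNCC1c1ccc(Cl)cc1Cl` — in this assay compound 3 gives "not determined" (no result reported)

For the measured compounds named here, compound 3 therefore stands without a number: in this assay it has no single value, and compound 1 shares the same position, so the only number in the set belongs to compound 2. Compound 4, `O=C(Nc1cc2cc[nH]c(=O)c2cc1Cl)C1CNCC1c1ccccc1`, has not yet been measured in this assay. It differs from compound 3 in one place: phenyl in place of 2,4-dichlorophenyl on a saturated ring carbon.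

No step between two measured compounds is available, so the size of the move from compound 3 to compound 4 in this assay cannot be anchored on a shown pair. Going by the values given here, since compound 3 has no number, nothing from the data indicates the direction of the change, and the expectation is that compound 4 should not fall far from the region where compound 2 sits, because compound 2 gives 210 nM and is the only compound with a number. On that basis compound 4 is expected to give about 250 nM in this assay, with a plausible range from 60 nM to 1000 nM.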

Compound 4, half-maximal inhibitory concentration: 89 nM
The estimate for compound 4 lay 2.8-fold (0.45 log units) above the measured number, within the range that was stated.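

In this assay the set now holds its first readable step at the saturated ring carbon of the five-membered non-aromatic ring with 1 nitrogen: a 2.4-fold lower number from compound 2 to compound 4 (0.37 log units; beyond the scatter) and this step lies beyond the usual scatter, though it is modest. For the compounds shown here, the exchange of pyridin-2-yl for phenyl therefore registers in the read-out, which the earlier compounds could not show with only one number among them. Compound 4 at 89 nM also gives the plain phenyl group a value against which other groups at this place can be set. Nothing offered here explains why the phenyl compound gives the lower number.

Going by these compounds, compound 3 has no number, so the step from 2,4-dichlorophenyl to phenyl cannot be read, and the effect of the two chlorine atoms on this read-out remains unknown. It also stays open how a cyclohexyl group in place of the phenyl, or a methoxy group or a primary amine carried on it, would compare with compound 4 in this assay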